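This account rests on a few compounds, and the source may have more. Where it says the series, first, only, none or still open, it means among the compounds named here.

Three compounds measured in an assay on HEK-293T cells for inhibition of diacylglycerol lipase-alpha (Homo sapiens), read by colorimetric assay (on this read-out lower numbers stand for stronger inhibition and higher numbers for weaker inhibition), set the scene. Compound 1 `COc1ccc(CC2CCCCN2C(=O)n2ncc(C(O)(c3ccc(F)cc3)c3ccc(F)cc3)n2)cc1` gives 5.01 nM in this assay, the lowest of the three numbers. Compound 3 `O=C(N1CCCCC1COc1ccccc1)n1ncc(C(O)(c2ccccc2)c2ccccc2)n1`, which carries a phenoxy group on the chain and two plain phenyl rings on the carbinol carbon, gives 7.94 nM; that number sits within the usual scatter of the number for compound 1, so the two cannot be told apart. Compound 2 `O=C(N1CCCCC1Cc1ccccc1)n1ncc(C(O)(C2CCCCC2)C2CCCCC2)n1`, which has two cyclohexyl rings in place of aromatic rings on the carbinol carbon, gives 100 nM, well beyond the scatter from compound 1.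

Compound 4 `O=C(N1CCCCC1COc1ccc(F)cc1)n1ncc(C(O)(c2ccc(F)cc2)c2ccc(F)cc2)n1` is the next step from compound 1. The difference between the two is 4-fluorophenoxy in place of 4-methoxyphenyl on a saturated chain carbon bound to a saturated ring carbon. This moves compound 1 toward the pattern of compound 3, while the two 4-fluorophenyl rings on the carbinol carbon stay as in compound 1. Going by the values given here, no pair of measured compounds differs in exactly this way, so the step has no direct precedent. Since compound 1 and compound 3 give numbers within the scatter of each other, the expectation is that the step from compound 1 to compound 4 stays within the scatter, in no firm direction: a 1.1-fold higher number from compound 1 to compound 4 (0.04 log units; within the scatter). Compound 4 is therefore expected to give about 5.5 nM in this assay, most likely between 2 nM and 15 nM.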

Compound 4, half-maximal inhibitory concentration: 5.01 nM
Compound 4: the middle estimate sits 1.1-fold (0.04 log units) above what was measured; low and high end bracket the measured number.
By their numbers in this assay, from the lowest: compounds 1, 4 and 3 (each within the scatter of the next); then compound 2.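

In this assay, putting 4-fluorophenoxy in place of 4-methoxyphenyl on a saturated chain carbon bound to a saturated ring carbon gives no change at the digits printed from compound 1 to compound 4 (within the scatter), with the two 4-fluorophenyl rings on the carbinol carbon held constant. Going by these compounds alone, this is the first direct reading at this position, and it shows that the measured inhibition survives an exchange in which the oxygen changes its place in the side chain and a fluorine replaces the methoxy group, read another way as 4-methoxybenzyl becoming (4-fluorophenoxy)methyl. Nothing available explains why the number holds, and no further measurement bears on it.

Two things change together in this one step, the link to the aromatic ring and the group on that ring, so the compounds shown cannot separate what each does alone, and the two changes might even offset each other. Going by these compounds, it also remains open how this position responds to groups of a different kind, such as an amine or a carboxylic acid on the aromatic ring, or a longer chain between the aromatic ring and the saturated ring.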